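A few compounds are considered here, and "the series" means these few. Any claim that something is new, unique, unknown or untested is made for them only; others in the source may bear on it.

In an ADME assay on Vero cells (Chlorocebus sabaeus) for cytotoxicity, read by neutral red uptake, tested at 98 ug/mL (on this read-out lower numbers stand for a stronger effect and higher numbers for a weaker effect at the one concentration tested), three compounds sharing one core have been measured. Compound 1 `O=C1CSC(c2cccc(Cl)c2)N1CCN1CCCCC1` gives 100%, and compound 2 `O=C1CSC(c2cccc(O)c2)N1CCN1CCCCC1` gives 100%. Among the measured compounds shown here, the only single-point step among them, no change at the digits printed from compound 1 to compound 2 (within the scatter), shows that swapping hydroxy for chloro on the aromatic carbon leaves the read-out where it was. Compound 3 `O=C1CSC(c2ccc([N+](=O)[O-])cc2)N1CCN1CCCCC1` gives 87%, the lowest of the three numbers; it sits below compound 1 and below compound 2 by the same margin, a gap beyond the usual scatter.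

Compound 4 `Cc1ccc(C2SCC(=O)N2CCN2CCCCC2)cc1` differs from compound 3 by methyl in place of nitro on an aromatic carbon. For the measured compounds named here, no measured step removes a nitro or adds a methyl, so the only guide is that compound 1 and compound 2, which carry other groups on that ring, both sit above compound 3. On that basis the step of a number 9 percentage points higher from compound 3 to compound 4 (within the scatter) is expected to move the number back up toward those two. Compound 4 is therefore expected to give about 96%, with a likely range from 84% to 100%.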

Compound 4, a percentage reported as activity, at one concentration (the size of the read-out at that concentration, not a potency): 100%
Beside the measured number, compound 4's estimate is 4 percentage points below it; measured number inside the range.
By their numbers in this assay, from the lowest: compound 3; then compounds 1, 2 and 4 (each within the scatter of the next).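

Swapping the group on this aromatic carbon, para to a large group, does move the read-out: methyl in place of nitro gives a number 13 percentage points higher from compound 3 to compound 4 (beyond the scatter), the first single-change step seen at this place. Compound 4 still carries a group on that carbon, yet the comparisons with the other two show no change at the digits printed from compound 2 to compound 4 (within the scatter) and no change at the digits printed from compound 1 to compound 4 (within the scatter), so having a group at this place does not by itself bring the number down, and among these four compounds only the nitro compound, compound 3, stands apart. No further measurement bears on what lies behind this difference. From the compounds shown here alone, whether the lower number is peculiar to nitro stays open, and a nitrile, a carboxylic acid or an amine on that carbon would test it. Going by these compounds, the effect of a longer chain, such as ethyl in place of methyl, also remains unknown.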